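The source may report more compounds than this note shows. Statements on the series, on what has been measured and on what is new or still open speak of the compounds shown alone.

Measured so far in a functional assay on BT-474 cells (Homo sapiens) for inhibition, read by fluorescence, with a stated time of 72 h (on this read-out lower numbers stand for stronger inhibition of growth and higher numbers for weaker inhibition of growth), are two compounds:

- compound 1 `COc1ccc(Nc2nc(N[C@H]3CC[C@H](N)CC3)nc3c2ncn3CCC(C)C)c(OC)c1` with 7900 nM
- compound 2 `CC(C)CCn1cnc2c(Nc3ccc(Cl)cc3)nc(N[C@H]3CC[C@H](N)CC3)nc21` with 5100 nM

Compound 2 stands level with compound 1 on these numbers, and no order can be read from a 1.5-fold lower number from compound 1 to compound 2 (0.19 log units; within the scatter) in this assay as it stands. Compound 3 `CCCCn1cnc2c(Nc3ccc(Cl)cc3)nc(N[C@H]3CC[C@H](N)CC3)nc21` carries one change against compound 2, hydrogen in place of methyl on a saturated chain carbon bound to two saturated chain carbons and so hydrogen takes the place of methyl on a saturated chain carbon bound to two saturated chain carbons, turning isopentyl into butyl. Going by the values given here, the only measured step concerns 4-chlorophenyl in place of 2,4-dimethoxyphenyl and leaves the isopentyl group untouched. Among the compounds with values here, no measured step speaks to this chain, so no large shift is expected in this assay and the estimate stays near compound 2 at 5100 nM as its anchor. The expected step is a 1.0-fold lower number from compound 2 to compound 3 (0.01 log units; within the scatter) and this remains an estimate. For compound 3 the estimated value is 5000 nM with an expected range from 2200 nM to 11000 nM.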

Compound 3, concentration for 50% growth inhibition: 7300 nM
For compound 3 the middle estimate is 1.5-fold (0.16 log units) below the measured one; the measured number falls inside the stated range.
By their numbers in this assay, from the lowest: compounds 2, 3 and 1 (each within the scatter of the next).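

Compound 3 is the first compound shown in which the chain on the shared core changes while the 4-chlorophenyl group stays in place. In this assay, hydrogen in place of methyl on a saturated chain carbon bound to two saturated chain carbons, which turns isopentyl into butyl, gives a step that lies within the scatter (a 1.4-fold higher number from compound 2 to compound 3 (0.16 log units; within the scatter)), so on this single pair the read-out does not separate the two chains. No measurement that bears on the reason for this result is at hand.

From the compounds shown here alone, whether a longer chain such as hexyl, a chain ending in an amine, or a cyclopentyl group at this place would shift the number stays open. Also open, going by these compounds, is whether butyl in place of isopentyl would read the same with 2,4-dimethoxyphenyl in place of 4-chlorophenyl.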